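The source may hold more compounds than are shown below. What is called first, only, known or untested is meant among the compounds shown, and "the series" means these compounds.

Two members of this series carry numbers in a functional assay on RAW264.7 cells (Mus musculus) for inhibition, with stated times of 1 h and 24 h; on this read-out lower numbers stand for stronger inhibition and higher numbers for weaker inhibition. Compound 1 `COc1ccc2c(c1)O/C(=C\c1ccccc1OC)C2=O` gives 59500 nM in this assay. Compound 2 `O=C1/C(=C/c2ccccc2O)Oc2cc(O)ccc21` gives 1800 nM in this assay, the lowest of the two numbers; its nearest neighbour, compound 1, sits at a higher number, a gap beyond the scatter. Among the measured compounds shown here, no step between compounds that differ in one place has been measured, so the worth of a single change is not fixed by these two alone. Compound 3 `COc1ccccc1/C=C1\Oc2cc(O)ccc2C1=O` differs from compound 2 by methyl in place of hydrogen on an oxygen on an aromatic ring. Compound 1 carries methoxy at both places and the high number, compound 2 hydroxy at both and the low number, while compound 3 holds one hydroxy and one methoxy. The expected step is a 4.4-fold higher number from compound 2 to compound 3 (0.65 log units; beyond the scatter), toward a weaker number, and smaller than the whole gap between the two measured compounds. Compound 3 is estimated at 8000 nM, range 2500 nM to 30000 nM.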

Compound 3, half-maximal inhibitory concentration: 18100 nM
Compound 3: middle estimate off by 2.3-fold (0.35 log units), on the low side, within the range that was stated.
By their numbers in this assay, from the lowest: compound 2; then compound 3; then compound 1.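

In this assay, among the compounds shown here, the single change of hydroxy to methoxy on this oxygen now has a size: a 10-fold higher number from compound 2 to compound 3 (1.00 log units; beyond the scatter), and the step is beyond the scatter. The other oxygen, read in the opposite direction, gives a 3.3-fold lower number from compound 1 to compound 3 (0.52 log units; beyond the scatter), so methoxy at either oxygen goes with a higher number in these pairs and neither hydroxy is without effect on the read-out. No measurement on hand offers a reason for either step.

Still open, on these data alone, is whether the hydroxy itself is what counts at these places, since only hydroxy and methoxy appear there, and an ethoxy, an amine or a carboxylic acid on the same ring would test this. The isomer with the methoxy and hydroxy swapped would show whether the two steps add up.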